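From 1-(hydroxymethyl)propyl to 1-(hydroxymethyl)-2-methylpropyl on a shared core

This account rests on a few compounds, and the source may have more. Where it says the series, first, only, none or still open, it means among the compounds named here.

Compound 1 `CC[C@@H](N)COc1nc(NC(=N)N)c2ncn(C(C)C)c2n1`: > 100000 nM (a limit)
Compound 2 `CC[C@H](CO)Nc1nc(NC(=N)N)c2ncn(C(C)C)c2n1`: 4500 nM
Compound 3 `CC(C)[C@@H](CO)Nc1nc(NC(=N)N)c2ncn(C(C)C)c2n1`: not yet measured

Within the data shown here, in a functional assay on MCF7 cells (Homo sapiens) for inhibition, read by fluorescence, with a stated time of 72 h (on this read-out higher numbers stand for weaker inhibition and lower numbers for stronger inhibition), compound 2 gives 4500 nM, the only true number available so far. Compound 1 gives > 100000 nM, and that value is a limit of the assay.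

Compound 3 differs from compound 2 in one place: 1-(hydroxymethyl)-2-methylpropyl in place of 1-(hydroxymethyl)propyl on a nitrogen on an aromatic ring. Here 1-(hydroxymethyl)-2-methylpropyl stands in place of 1-(hydroxymethyl)propyl on a nitrogen on an aromatic ring.

Among the measured compounds shown here, only one measured step bears on this change. That step, an at least 22-fold lower number from compound 1 to compound 2 (1.34 log units; beyond the scatter), is large and beyond the scatter, and it came from putting (1-(hydroxymethyl)propyl)amino in place of 2-aminobutoxy on an aromatic carbon. It replaced the whole group, whereas the new change keeps the hydroxymethyl and the amino link and alters only the chain. For the measured compounds named here, no measured step tests a change of that smaller kind, so its size cannot be carried over.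

The expected step, a 1.1-fold higher number from compound 2 to compound 3 (0.05 log units; within the scatter), is not expected to go beyond the scatter, though the range stays wide in both directions. For compound 3 the estimated value is 5000 nM, with an expected range from 1700 nM to 15000 nM.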

Compound 3, half-maximal inhibitory concentration: 2100 nM
Beside the measured number, compound 3's estimate is 2.4-fold (0.38 log units) above it, within the range that was stated.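

In this assay, the chain on the nitrogen on the aromatic ring turns out to respond to a change much smaller than replacing the whole group: 1-(hydroxymethyl)-2-methylpropyl in place of 1-(hydroxymethyl)propyl gives a 2.1-fold lower number from compound 2 to compound 3 (0.33 log units; beyond the scatter). The hydroxymethyl and the amino link stay in place here, so this is the first step shown that alters only the chain, and it is modest but beyond the scatter. Against the 2-aminobutoxy group, (1-(hydroxymethyl)-2-methylpropyl)amino gives an at least 47-fold lower number from compound 1 to compound 3 (1.67 log units; beyond the scatter), and the value of compound 1 is a limit rather than a number, so the full size of that step stays unfixed: the limit of > 100000 nM in this assay, at which 1 of the 3 values shown sits.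

The compounds shown leave open whether the trend from 1-(hydroxymethyl)propyl to 1-(hydroxymethyl)-2-methylpropyl continues with a tert-butyl, a cyclohexyl or a phenyl group on the carbon that carries the hydroxymethyl. They also leave open what the hydroxymethyl itself contributes, which a methoxymethyl group or a plain alkyl chain at the same place would test.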